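Swapping a Sulfur-Linked Chain for a Cyclohexylsulfonyl Group

A few compounds are considered here, and "the series" means these few. Any claim that something is new, unique, unknown or untested is made for them only; others in the source may bear on it.

Of the compounds shown here, three sharing one core have been tested for antagonist activity in an assay on CHO-K1 cells for antagonist activity at transient receptor potential cation channel subfamily V member 1 (Homo sapiens), read by FLIPR; a higher number here means a weaker inhibitor, a lower number a stronger inhibitor. Compound 1 `CCCCCSc1nc(C(F)(F)F)ccc1CNC(=O)C(C)c1ccc(NS(C)(=O)=O)c(F)c1` gives 2.5 nM. Compound 2 `CC(C)CCSc1nc(C(F)(F)F)ccc1CNC(=O)C(C)c1ccc(NS(C)(=O)=O)c(F)c1` gives 0.7 nM. Compound 3 `CC1CCN(CCCSc2nc(C(F)(F)F)ccc2CNC(=O)C(C)c2ccc(NS(C)(=O)=O)c(F)c2)CC1` gives 2.9 nM, the highest of the three numbers; it sits within the scatter of compound 1 but clearly above compound 2, as a 4.1-fold higher number from compound 2 to compound 3 (0.62 log units; beyond the scatter) shows, and a 1.2-fold higher number from compound 1 to compound 3 (0.06 log units; within the scatter) is within the scatter.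

Compound 4 `CC(C(=O)NCc1ccc(C(F)(F)F)nc1S(=O)(=O)C1CCCCC1)c1ccc(NS(C)(=O)=O)c(F)c1` differs from compound 3 on an aromatic carbon of a six-membered aromatic ring with 1 nitrogen, next to the ring nitrogen: cyclohexylsulfonyl in place of (3-(4-methylpiperidin-1-yl)propyl)sulfanyl on an aromatic carbon. The measured steps all alter only the chain attached to the sulfur: a 3.6-fold lower number from compound 1 to compound 2 (0.55 log units; beyond the scatter) and a 4.1-fold higher number from compound 2 to compound 3 (0.62 log units; beyond the scatter) were modest, and a 1.2-fold higher number from compound 1 to compound 3 (0.06 log units; within the scatter) was within the scatter. Going by the values given here, none changes the sulfur itself, so the present change has no direct precedent.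

Given that every chain variant stayed potent, compound 4 is expected to remain active, with a modestly higher number estimated at 6 nM (range 1.5 nM to 30 nM), corresponding to an expected 2.1-fold higher number from compound 3 to compound 4 (0.32 log units; beyond the scatter).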

Compound 4, inhibition constant: "not active" (no number reported)
Compound 4 has no reported number here; no gap can be computed for the estimate.
By their numbers in this assay, from the lowest: compound 2; then compounds 1 and 3 (each within the scatter of the next).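

In this assay, going by these compounds alone, compound 4 is reported as "not active" without a number, so no step from compound 3 to compound 4 can be read. The compounds shown leave open whether the cyclohexylsulfonyl group or the sulfur's changed state decides this outcome. No available data bear on its cause.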